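From a Hydroxybutyl Chain to a Benzyl Group

The source may hold more compounds than are shown below. What is called first, only, known or untested is meant among the compounds shown, and "the series" means these compounds.

Compound 3 `CSc1nc(NCCCCCO)c2cccnc2n1` stands at the upper edge of the numbers shown. In a functional assay on HT-29 cells (Homo sapiens) for cytotoxicity, read by MTT assay, with a stated time of 72 h (a lower number here means that less compound is tolerated, a higher number that more compound is tolerated), compound 3 gives > 100000 nM, which is a limit of the assay and not a number. Compound 4 `CSc1nc(NCc2ccccc2)c2cccnc2n1` differs from it by phenyl in place of 4-hydroxybutyl on a saturated chain carbon bound to a nitrogen on an aromatic ring. For the measured compounds named here, no measured step follows this change; the only measured step, an at least 11-fold higher number from compound 1 to compound 2 (1.05 log units; beyond the scatter), concerns a different position. Its two compounds are nevertheless the nearest relatives of compound 4. In this assay compound 1 `CSc1ccc(CNc2nc(SC)nc3ncccc23)cc1` gives 8750 nM. Compound 2 `COc1ccc(CNc2nc(SC)nc3ncccc23)cc1` gives > 100000 nM in this assay, again a limit of the assay. Going by the values given here, the one piece of evidence on the measured steps is the limit of > 100000 nM in this assay, at which 2 of the 3 values shown sit. Compound 4 is therefore expected to fall somewhere between what compound 1 and compound 2 show, with a real chance that only a limit is reported once more. The step expected is an at least 2.0-fold lower number from compound 3 to compound 4 (0.30 log units; that floor lies within the scatter). Compound 4 is estimated at 50000 nM, within a range from 8000 nM to 200000 nM.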

Compound 4, concentration lethal to 50% of the cells: > 100000 nM
Compound 4: no number, only a limit; the forecaster's own chance of this, stated with the estimate: 45%; middle value at least 2.0-fold (0.30 log units) from the limit.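

Hydrogen in place of methylsulfanyl on an aromatic carbon gives an at least 11-fold higher number from compound 1 to compound 4 (1.05 log units; beyond the scatter) in this assay, a large step of the kind that methoxy in place of methylsulfanyl also gave, an at least 11-fold higher number from compound 1 to compound 2 (1.05 log units; beyond the scatter). Of the benzyl compounds shown, only compound 1, which carries methylsulfanyl, gives a number rather than a limit of the assay. The steps from compound 3 and from compound 2 to compound 4 cannot be read because both ends of each are limits: the limit of > 100000 nM in this assay, at which 3 of the 4 values shown sit.

As far as these compounds go, it remains open whether a group such as an amine or a carboxylic acid in place of methylsulfanyl would also give a number. From the compounds shown here alone, it is equally open how compound 2, compound 3 and compound 4 rank among themselves, and whether a longer chain in place of 4-hydroxybutyl would give a readable value.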